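This account rests on a few compounds, and the source may have more. Where it says the series, first, only, none or still open, it means among the compounds named here.

Compound 3 `NC1=NC2(CCSCC2)N(OCCCOc2ccccc2Br)C(N)=N1` gives 88.7% in an assay on isolated protein for inhibition of Dihydrofolate reductase (Homo sapiens), read by spectrophotometry, using NADPH, with stated times of 5 s and 6 min, tested at 5 uM (on this read-out higher numbers stand for a stronger effect at the one concentration tested and lower numbers for a weaker effect), the higher of the two plain numbers shown; compound 2 `COc1ccc(OCCCON2C(N)=NC(N)=NC23CCSCC3)cc1` gives 81.3%, within the scatter of it. Compound 1 `NC1=NC2(CCSCC2)N(OCCCOc2ccc(Cl)cc2)C(N)=N1` is reported only as > 90%, a limit of this assay rather than a number (the limit of > 90% in this assay, at which 1 of the 3 values shown sits). Within the data shown here, two measured steps bear on an exchange of the aryl group at this place: the step of a number 7.4 percentage points higher from compound 2 to compound 3 (within the scatter) and the step of a number at least 1.3 percentage points lower from compound 1 to compound 3 (that floor lies within the scatter), neither beyond the scatter. Compound 4 `NC1=NC2(CCSCC2)N(OCCCOc2ccc(Cl)c(Cl)c2)C(N)=N1` carries 3,4-dichlorophenyl in place of 2-bromophenyl on an oxygen on a saturated carbon. No step beyond the scatter is expected, a number 1.3 percentage points higher from compound 3 to compound 4 (within the scatter). Compound 4 is estimated at 90%, between 82% and 97% in this assay, with a fair chance that only the limit is reported.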

Compound 4, a percentage reported as inhibition, at one concentration (the size of the read-out at that concentration, not a potency): 88.4%
For compound 4 the middle estimate is 1.6 percentage points above the measured one; the measured number falls inside the stated range.
By their numbers in this assay, from the lowest: compounds 2, 4 and 3 (each within the scatter of the next). At a limit, above all of these: compound 1.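

The 3,4-dichlorophenyl group adds a further aryl pattern at this place and stays level in this assay: a number 0.3 percentage points lower from compound 3 to compound 4 (within the scatter), and a number 7.1 percentage points higher from compound 2 to compound 4 (within the scatter). Chloro in place of hydrogen on an aromatic carbon also gives no step beyond the scatter: a number at least 1.6 percentage points lower from compound 1 to compound 4 (that floor lies within the scatter). Compound 1 remains a limit rather than a number: the limit of > 90% in this assay, at which 1 of the 4 values shown sits.

The values, each read at one concentration, give no potency order among these compounds. On these data alone, the effect of an amine or a carboxylic acid on the aromatic ring, or of a longer chain, stays open.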